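The source may hold more compounds than are shown below. What is called first, only, known or untested is meant among the compounds shown, and "the series" means these compounds.

In a functional assay on HT-29 cells (Homo sapiens) for cytotoxicity, read by sulforhodamine B assay, with a stated time of 72 h (a higher number here means a weaker inhibitor, a lower number a stronger inhibitor), compound 1 `COc1ccc(/C(F)=C\c2cc(OC)c(OC)c(OC)c2)cc1O` gives 28.9 nM and compound 2 `COc1ccc(/C(F)=C\c2cc(OC)c(OC)c(OC)c2)cc1[N+](=O)[O-]` gives 202 nM, so compound 2 holds the higher of the two numbers and is the weaker inhibitor of the pair. Among the compounds with values here, the one measured step, a 7.0-fold higher number from compound 1 to compound 2 (0.84 log units; beyond the scatter), puts nitro in place of hydroxy on an aromatic carbon and lies beyond the scatter. Compound 3 `COc1ccc(/C(F)=C\c2cc(OC)c(OC)c(OC)c2)cc1N` differs from compound 2 at that same carbon: amino in place of nitro on an aromatic carbon. This is amino in place of nitro on an aromatic carbon, ortho to a methoxy group. Within the data shown here, no measured compound carries amino, so that single step is the only guide, and the size of any change remains uncertain. A step of similar size in the opposite direction is expected, going by compound 1 at 28.9 nM. The expected step is a 5.1-fold lower number from compound 2 to compound 3 (0.70 log units; beyond the scatter). The estimate in this assay for compound 3 is 40 nM, with an expected range of 10 nM to 160 nM.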

Compound 3, half-maximal inhibitory concentration: 5 nM
Compound 3: middle estimate off by 8.0-fold (0.90 log units), on the high side; measured number outside the range, below it.
By their numbers in this assay, from the lowest: compound 3; then compound 1; then compound 2.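

At this carbon, ortho to a methoxy group, the earlier pair showed only that nitro gives a higher number than hydroxy; the new result shows that hydroxy is not the best of the groups shown, since amino gives a 5.8-fold lower number from compound 1 to compound 3 (0.76 log units; beyond the scatter). Exchanging nitro for amino gives a 40-fold lower number from compound 2 to compound 3 (1.61 log units; beyond the scatter), so the three groups now span a wide range at one carbon, with compound 3 the strongest inhibitor of the three in this assay and every step between them beyond the scatter. Nothing measured here explains this order.

From the compounds shown here alone, it remains open whether a dimethylamino group or an acetamide at this carbon would keep the low number of compound 3. The compounds shown also leave open whether the same order of amino, hydroxy and nitro would hold on the core with the fluorine replaced by hydrogen.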